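Swapping the Acid for a Pyrrolidine Amide

The source may report more compounds than this note shows. Statements on the series, on what has been measured and on what is new or still open speak of the compounds shown alone.

Compound 1, `O=C(O)c1ccc(NCc2cccc(Oc3ccccc3)c2)cc1`: in a functional assay on CHO cells for agonist activity at Free fatty acid receptor 1 (Homo sapiens) (a lower number here means that less compound is needed, a higher number that more compound is needed for the effect), compound 1 gives < 10000 nM, which is a limit of the assay and not a number.
Compound 2, `O=C(O)[C@@H]1C[C@H]1c1ccc(NCc2cccc(Oc3ccccc3)c2)cc1`: in this assay compound 2 gives 562 nM.

Compound 2 thus holds the only real number shown; the other value is a limit. As far as these compounds go, the step that the limit leaves unreadable from compound 1 to compound 2 cannot be sized because of the limit of < 10000 nM in this assay, at which 1 of the 2 values shown sits, so its direction and size stay unknown.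

Compound 3, `O=C(CCc1ccc(NCc2cccc(Oc3ccccc3)c2)cc1)N1CCCC1`, differs from compound 2 by 2-((pyrrolidin-1-yl)carbonyl)ethyl in place of 2-carboxycyclopropyl on an aromatic carbon. Going by the values given here, no measured step bears on this change: the single step recorded exchanges one acid-bearing group for another rather than removing the acid, and even that step is unreadable. The expectation for compound 3 therefore rests on compound 2 alone, and on the fact that the acid leaves entirely. Compound 3 is estimated at 6000 nM, with a range from 1200 nM to 30000 nM. This estimate means a step of an 11-fold higher number from compound 2 to compound 3 (1.03 log units; beyond the scatter) toward more compound being needed.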

Compound 3, half-maximal effective concentration: 115 nM
Estimate against measurement, compound 3: 52-fold (1.72 log units) above; measured number below the stated range.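

In this assay, this position on the aromatic carbon does not need a carboxylic acid: with 2-((pyrrolidin-1-yl)carbonyl)ethyl in place of 2-carboxycyclopropyl, the data show a 4.9-fold lower number from compound 2 to compound 3 (0.69 log units; beyond the scatter). Less compound is needed for the effect, even though the new group has 0 hydrogen-bond donors and no defined stereocentres, while the old group has 1 hydrogen-bond donor and 2 defined stereocentres. The steps from compound 1 cannot be read, so this comparison rests on compound 2 alone: the limit of < 10000 nM in this assay, at which 1 of the 3 values shown sits.

This one change swaps the acid for an amide, the three-membered ring for an open chain, and adds a pyrrolidine ring, and the compounds shown do not separate these parts. A 2-carboxyethyl group or an open-chain diethylamide at the same place would help tell which part goes with the step.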